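Rearranging the side chain: from compound 1 to compound 4

The source may report more compounds than this note shows. Statements on the series, on what has been measured and on what is new or still open speak of the compounds shown alone.

Of the compounds shown here, three have been measured in a functional assay on the whole organism (stomach) for inhibition, with Rattus norvegicus as the target, at a dose of 100 mg/kg by the intraduodenal route; on this read-out higher numbers stand for more inhibition at the one dose given (going by the name of the read-out) and lower numbers for less inhibition. Compound 1 `N=C(S)CCCn1nc(-c2ccccc2)ccc1=O` stands highest of the three: in this assay compound 1 gives 75.6%. Compound 2 `Cc1ccc(=O)n(CC(=N)S)n1` is nearest to it and gives 31.5% in this assay, a difference beyond the scatter. Compound 3 `CC1=NN(C(C)CC(=N)S)C(=O)CC1` lies furthest away; in this assay compound 3 gives 17.4%, again beyond the scatter. No pair among these three differs in a single place, so no step between measured compounds can be read off directly.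

Compound 4 `CC(CC(=N)S)n1nc(-c2ccccc2)ccc1=O` is the unmeasured member and has the same atoms as compound 1, joined differently. The change is a group of 6 heavy atoms (4 carbon, 1 nitrogen, 1 sulfur; no ring) in place of a group of 6 heavy atoms (4 carbon, 1 nitrogen, 1 sulfur; no ring), on an aromatic nitrogen: a group of 6 heavy atoms (4 carbon, 1 nitrogen, 1 sulfur; no ring) replaces a group of the same count and kind on the aromatic nitrogen of the shared core, next to the ring nitrogen. The phenyl group and the core are kept. Going by the values given here, since no measured pair shows such a rearrangement, the size of the step is uncertain; a moderate decrease beyond the scatter is expected, as compound 3 carries a branched chain of the same kind and gives 17.4%, though on a different core. The expected step from compound 1 to compound 4 is a number 25.6 percentage points lower from compound 1 to compound 4 (beyond the scatter). Compound 4 is therefore estimated at 50% in this assay, within a range of 25% to 75%.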

Compound 4, a percentage reported as inhibition, in the whole organism at one dose (the size of the read-out at that dose, not a potency): 15.5%
Compound 4: middle estimate off by 34.5 percentage points, on the high side; measured number outside the range, below it.
By their numbers in this assay, from the lowest: compounds 4 and 3 (each within the scatter of the next); then compound 2; then compound 1.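

In this assay, going by these compounds alone, rearranging the side chain on the aromatic nitrogen while keeping the phenyl group and the shared core gives a number 60.1 percentage points lower from compound 1 to compound 4 (beyond the scatter) as the only change in the pair. Within the data shown here, the group that leaves and the group that enters have the same count under every heading, 6 heavy atoms (4 carbon, 1 nitrogen, 1 sulfur) with no ring, so the read-out at this position depends on how these atoms are joined and not merely on which atoms are present, something no earlier compound could show. No measurement on hand accounts for the size of this step.

The compounds shown leave open whether a longer chain on this aromatic nitrogen, or a carboxylic acid or an amine in place of the end of the chain, would hold the number at the level where compound 1 stands, 75.6% in this read-out. They also leave open whether a step of this size would recur on a core without the phenyl group, as this single pair is the only one that isolates the rearrangement.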